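The source may hold more compounds than are shown below. What is called first, only, known or untested is meant among the compounds shown, and "the series" means these compounds.

The compounds here share one core and are compared in a functional assay on NCI-H522 cells (Homo sapiens) for cytotoxicity, read by sulforhodamine B assay, with a stated time of 48 h; on this read-out lower numbers stand for higher toxicity in this test and higher numbers for lower toxicity in this test. Compound 1 `ClCc1cccc(Cn2cnc3c(Cl)nc(Cl)nc32)c1` carries a chloro group on that core and gives 17000 nM in this assay. Going by the values given here, compound 1 is the only compound with a number here; the other value shown is a limit. Compound 2 `ClCc1ccccc1Cn1cnc2ncnc(Cl)c21` gives > 100000 nM in this assay, which is a limit of the assay rather than a number. Compound 2 thus sits at the limit of > 100000 nM in this assay, at which 1 of the 2 values shown sits.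

Compound 3 `Nc1nc(Cl)c2ncn(Cc3cccc(CCl)c3)c2n1` has not yet been tested. Its change from compound 1 is amino in place of chloro on an aromatic carbon: the amino group enters on an aromatic carbon of a six-membered aromatic ring with 2 nitrogen, between two ring nitrogen atoms, where the chloro group sat. Among the compounds with values here, no measured pair shows this exact change, so the size of the step in this assay is open; a shift of modest size in either direction, possibly no more than the usual scatter, seems plausible. Compound 3 is expected to give 25000 nM, within a range from 8000 nM to 80000 nM. The expected step from compound 1 to compound 3 is therefore a 1.5-fold higher number from compound 1 to compound 3 (0.17 log units; within the scatter).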

Compound 3, concentration lethal to 50% of the cells: 81300 nM
Beside the measured number, compound 3's estimate is 3.3-fold (0.51 log units) below it, and the stated range ends below it.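

In this assay, placing an amino group where the chloro group sat, on the aromatic carbon between two ring nitrogen atoms, gives a 4.8-fold higher number from compound 1 to compound 3 (0.68 log units; beyond the scatter), a shift toward lower toxicity in this test. Going by these compounds alone, compounds 1 and 3 differ only in this one exchange, so this is the first direct evidence that the group at this position of the shared core affects the read-out, and that the change from chloro to amino does so by more than the usual scatter. Nothing measured here gives a reason for the size or direction of this step.

A single pair cannot show whether this shift is particular to the amino group or would also appear with another replacement at this position, such as a methoxy group or a dimethylamino group. It also leaves open whether the same exchange would have a similar effect on the other chloro group, or on a core carrying a different substituent pattern.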